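Working notes: ethoxy in place of methyl, compound 4

This account rests on a few compounds, and the source may have more. Where it says the series, first, only, none or still open, it means among the compounds named here.

Measured in a physicochemical assay, with a stated time of 30 min; a higher number here means a weaker inhibitor, a lower number a stronger inhibitor:
- compound 1 `COc1cc2c(cc1OC)C(=O)C(C(=O)Nc1ccccc1)C2`: 61.3 ug/mL
- compound 2 `COc1cc2c(cc1OC)C(=O)C(C(=O)Nc1ccc(F)cc1)C2`: 55 ug/mL
- compound 3 `COc1cc2c(cc1OC)C(=O)C(C(=O)Nc1ccccc1C)C2`: 43.7 ug/mL

Not yet measured: compound 4 `CCOc1ccccc1NC(=O)C1Cc2cc(OC)c(OC)cc2C1=O`

Compound 3, at 43.7 ug/mL, lies within the scatter of both other compounds: a 1.4-fold lower number from compound 1 to compound 3 (0.15 log units; within the scatter) and a 1.3-fold lower number from compound 2 to compound 3 (0.10 log units; within the scatter). The change to compound 4 is ethoxy in place of methyl on an aromatic carbon, ortho to a large group: ethoxy in place of methyl on an aromatic carbon. Within the data shown here, no measured step covers this exchange directly. The closest evidence is those two steps and a 1.1-fold lower number from compound 1 to compound 2 (0.05 log units; within the scatter), and none of the three leaves the scatter in this assay. Among the measured compounds shown here, no measured compound carries ethoxy, so the range stays wide. The expected change is none beyond the scatter, with an estimated 1.0-fold higher number from compound 3 to compound 4 (0.01 log units; within the scatter). For compound 4 the estimate is 45 ug/mL, with an expected range of 25 ug/mL to 80 ug/mL.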

Compound 4, half-maximal inhibitory concentration: 63.7 ug/mL
Estimate against measurement, compound 4: 1.4-fold (0.15 log units) below; low and high end bracket the measured number.
By their numbers in this assay, from the lowest: compounds 3, 2, 1 and 4 (each within the scatter of the next).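

In this assay ethoxy on this aromatic carbon, ortho to a large group, stays within the scatter against methyl (a 1.5-fold higher number from compound 3 to compound 4 (0.16 log units; within the scatter)) and against hydrogen (a 1.0-fold higher number from compound 1 to compound 4 (0.02 log units; within the scatter)). Among these compounds, this place now carries hydrogen, methyl and ethoxy, with ethoxy adding a hydrogen-bond acceptor, and no step among them leaves the scatter. No supporting data bear on these steps.

On these data alone, whether an amine or a carboxylic acid on this aromatic carbon would move the number beyond the scatter stays open. The same holds for a chain longer than ethoxy.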